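This account rests on a few compounds, and the source may have more. Where it says the series, first, only, none or still open, it means among the compounds named here.

Measured compounds:
- Compound 1 `Cc1cc(C)cc(/C=C\c2ccc(N3CCNC3=O)cc2)c1` gives 10 nM
- Compound 2 `COc1cc(/C=C\c2ccc(N3CCNC3=O)cc2)cc(OC)c1OC` gives 2.4 nM

Both values come from a functional assay on M21 cells (Homo sapiens) for inhibition, read by sulforhodamine B assay, with a stated time of 48 h; a lower number here means a stronger inhibitor, a higher number a weaker inhibitor. Compound 2 gives the lower of the two numbers, and in this assay compound 2 gives 2.4 nM, while in this assay compound 1 gives 10 nM; the gap between them is beyond the usual scatter, so compound 2 is the stronger inhibitor of the two.

Compound 3 `COc1cc(/C=C/c2ccc(N3CCNC3=O)cc2)cc(OC)c1OC` has not yet been measured. Its difference from compound 2 is the two compounds have the same atoms and bonds and differ only in configuration as drawn: 1 of 1 stereo elements differ; a double bond is drawn Z in compound 2 and E in compound 3. Going by the values given here, no pair of measured compounds shows what such a change in configuration does here, so the expectation rests on the change alone. A large step is expected, in the direction of a weaker inhibitor: the step from compound 2 to compound 3 is estimated as a 210-fold higher number from compound 2 to compound 3 (2.32 log units; beyond the scatter). For compound 3 the value is estimated at 500 nM, with a range from 50 nM to 5000 nM.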

Compound 3, half-maximal inhibitory concentration: 550 nM
For compound 3 the middle estimate is 1.1-fold (0.04 log units) below the measured one; low and high end bracket the measured number.
By their numbers in this assay, from the lowest: compound 2; then compound 1; then compound 3.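

Changing the double bond from Z to E gives a 230-fold higher number from compound 2 to compound 3 (2.36 log units; beyond the scatter) in this assay, so its configuration matters greatly for this inhibition. Going by these compounds alone, the earlier compounds both carry the Z double bond and could not show this, whereas this pair isolates the configuration as the single change. The whole step can be assigned to the geometry of the double bond because nothing else separates the two compounds: the fact that compounds 2 and 3 differ only in the configuration as drawn

Going by these compounds, it remains open whether the same large penalty would apply to the E form of compound 1, since this one pair shows the change only with the substituents of compound 2. On these data alone, it is also open how an amine or a carboxylic acid on the shared core would behave with either configuration of the double bond.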